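Chloro in Place of Fluoro on an Aromatic Carbon

A few compounds are considered here, and "the series" means these few. Any claim that something is new, unique, unknown or untested is made for them only; others in the source may bear on it.

Within the data shown here, in a functional assay on K562 cells (Homo sapiens) for cytotoxicity, read by trypan blue exclusion, with a stated time of 96 h (a lower number here means a stronger inhibitor, a higher number a weaker inhibitor), compound 1 `COC(=O)CCNc1cc(CS(=O)(=O)/C=C/c2c(OC)cc(OC)cc2OC)ccc1OC` gives 1000 nM, and compound 2 `COC(=O)C(Nc1cc(CS(=O)(=O)/C=C/c2c(OC)cc(OC)cc2OC)ccc1OC)c1ccc(F)cc1` gives 800 nM, so compound 2 stands within the scatter of the only other measured compound. Compound 3 `COC(=O)C(Nc1cc(CS(=O)(=O)/C=C/c2c(OC)cc(OC)cc2OC)ccc1OC)c1ccc(Cl)cc1` differs from compound 2 by chloro in place of fluoro on an aromatic carbon. Among the measured compounds shown here, the one measured step, a 1.3-fold lower number from compound 1 to compound 2 (0.10 log units; within the scatter), replaced a whole group on the nitrogen and stayed within the scatter, though it does not test this halogen exchange. No step beyond the scatter is therefore expected in this assay. For compound 3 the estimated value is 700 nM, with an expected range of 300 nM to 1600 nM. The expected step is a 1.1-fold lower number from compound 2 to compound 3 (0.06 log units; within the scatter).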

Compound 3, half-maximal inhibitory concentration: 200 nM
Compound 3: middle estimate off by 3.5-fold (0.54 log units), on the high side, and the stated range ends above it.
By their numbers in this assay, from the lowest: compound 3; then compounds 2 and 1 (each within the scatter of the next).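

In this assay the halogen on the 4-chlorophenyl group matters: chloro in place of fluoro on an aromatic carbon gives a 4.0-fold lower number from compound 2 to compound 3 (0.60 log units; beyond the scatter) as a step beyond the scatter, from one heavy atom exchanged. The earlier change of the whole group on the nitrogen had stayed within the scatter, whereas with chloro in place the same comparison gives a 5.0-fold lower number from compound 1 to compound 3 (0.70 log units; beyond the scatter) and passes beyond it. Nothing measured here accounts for this difference between the halogens. Still open, from the compounds shown here alone, is how bromo or methoxy would read at this place, and whether a carboxylic acid could stand in for the methyl ester with the chloro kept.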